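Removing a fluoro from a sulfonamide: effect on cell toxicity

The compounds below may be only part of what the source reports. "The series", "measured", "known", "first", "only" and "open" are said of these compounds alone.

Measured compounds:
compound 1 `O=S(=O)(Nc1ccc(-c2nc3ccccc3o2)cc1)c1ccc(F)c(C(F)(F)F)c1`: 82000 nM
compound 2 `O=S(=O)(Nc1ccc2oc(-c3ccccc3)nc2c1)c1ccc(O)cc1`: > 100000 nM

In an ADME assay on HEK293 cells (Homo sapiens) for cytotoxicity, read by resazurin assay, with a stated time of 48 h (on this read-out lower numbers stand for higher toxicity in this test and higher numbers for lower toxicity in this test), compound 1 gives 82000 nM. Compound 2 gives only a limit of the test, > 100000 nM; this is the limit at which a part of the values shown sit (the limit of > 100000 nM in this assay, at which 1 of the 2 values shown sits). Compound 1 therefore holds the only number shown. Compound 3 `O=S(=O)(Nc1ccc(-c2nc3ccccc3o2)cc1)c1cccc(C(F)(F)F)c1` differs from compound 1 by hydrogen in place of fluoro on an aromatic carbon. Among the compounds with values here, with no comparable step among the measured pairs, the step from compound 1 to compound 3 is expected to stay within the usual scatter, if anything toward lower toxicity, as a 1.1-fold higher number from compound 1 to compound 3 (0.04 log units; within the scatter). Compound 3 is thus estimated at 90000 nM, between 45000 nM and 180000 nM.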

Compound 3, half-maximal cytotoxic concentration: > 100000 nM
Compound 3 gave a limit, no number (the forecaster's own chance of this, stated with the estimate: 40%); at least 1.1-fold (0.04 log units) between middle value and limit.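

In this assay, the fluoro ortho to a trifluoromethyl group gives the only single-place step shown, and it reads as an at least 1.2-fold higher number from compound 1 to compound 3 (0.08 log units; that floor lies within the scatter). Compound 3 gives > 100000 nM, which is a limit and not a number. The true size of the step cannot be told because the reading stops at that limit: the limit of > 100000 nM in this assay, at which 2 of the 3 values shown sit. The compounds shown leave open what a chlorine, a methoxy group or an amine would give on this aromatic carbon. They also leave open whether this fluoro counts for anything once the trifluoromethyl group is replaced by a nitrile.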